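The source may report more compounds than this note shows. Statements on the series, on what has been measured and on what is new or still open speak of the compounds shown alone.

Measured so far: compound 1 `CC/N=C(\S)NCCCCCn1nc(-c2ccccc2)ccc1=O` gives 66.4% in a functional assay on the whole organism with Rattus norvegicus as the target, at a dose of 100 mg/kg; a lower number here means less inhibition, a higher number more inhibition at the dose given (going by the name of the read-out); compound 2 `CC/N=C(\S)NCCCn1nc(-c2ccccc2)ccc1=O` gives 39% in this assay; compound 3 `N#CNC(=N)NCCCCCCn1nc(-c2ccccc2)ccc1=O` gives 20.5% in this assay.

Compound 3 stands lowest of the three numbers. Its nearest neighbour is compound 2, whose number lies higher by a gap beyond the scatter, and the furthest is compound 1, higher still, as the step of a number 45.9 percentage points lower from compound 1 to compound 3 (beyond the scatter) shows.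

Compound 4 `C/N=C(\S)N(C)CCCCn1nc(-c2ccccc2)ccc1=O` has not yet been measured in this assay. It differs from compound 3 by a group of 6 heavy atoms (3 carbon, 2 nitrogen, 1 sulfur; no ring) in place of a group of 8 heavy atoms (4 carbon, 4 nitrogen; no ring), on a saturated chain carbon, four bonds along the chain from an aromatic nitrogen. Among the compounds with values here, two measured steps bear on this. The step of a number 45.9 percentage points lower from compound 1 to compound 3 (beyond the scatter) runs in the opposite sense to the change now considered: there a group of six heavy atoms with one sulfur gave way to a group with four nitrogens, and the number fell by a large amount. The step of a number 27.4 percentage points lower from compound 1 to compound 2 (beyond the scatter) shows that shortening the chain carrying the group also lowered the number, by a modest amount. Compound 4 carries the sulfur-containing group on a chain four bonds from the aromatic nitrogen, between the chain lengths of compound 1 and compound 2. A rise from compound 3 is therefore expected, of a size around a number 29.5 percentage points higher from compound 3 to compound 4 (beyond the scatter). Compound 4 is estimated to give 50% in this assay, with a range from 30% to 70%.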

Compound 4, a percentage reported as inhibition, in the whole organism at one dose (the size of the read-out at that dose, not a potency): 17.5%
Estimate against measurement, compound 4: 32.5 percentage points above; measured number below the stated range.
By their numbers in this assay, from the lowest: compounds 4 and 3 (each within the scatter of the next); then compound 2; then compound 1.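

In this assay, replacing the group of 8 heavy atoms (4 carbon, 4 nitrogen) with a group of 6 heavy atoms (3 carbon, 2 nitrogen, 1 sulfur), on a saturated chain carbon, four bonds along the chain from an aromatic nitrogen, gives a number 3 percentage points lower from compound 3 to compound 4 (within the scatter), so a sulfur-bearing group here does not by itself secure a high number. Within the data shown here, the sulfur-bearing groups also differ widely among themselves, with a number 21.5 percentage points lower from compound 2 to compound 4 (beyond the scatter) and a number 48.9 percentage points lower from compound 1 to compound 4 (beyond the scatter), and compound 4 therefore goes against the reading from the first two compounds that the number simply follows chain length. Each of these two steps changes the group as well as where it sits, and nothing measured on these compounds offers an explanation for the result.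

The compounds shown leave open how much of the gap separating compound 4 from the other two sulfur-bearing compounds belongs to the chain and how much to the make-up of the group, as no pair here changes one while holding the other fixed. They also leave open how a primary amine or a carboxylic acid at the chain end would read in this assay.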